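Cyclopropylamino in place of ethyl(methyl)amino on a shared core

The source may hold more compounds than are shown below. What is called first, only, known or untested is meant among the compounds shown, and "the series" means these compounds.

Measured compounds:
- Compound 1, `CNc1ncnc2c1ncn2Cc1cccc(F)c1`: 7 mg/kg
- Compound 2, `CNc1ncnc2c1ncn2Cc1c(F)cccc1F`: 2 mg/kg
- Compound 3, `CCN(C)c1ncnc2c1ncn2Cc1ccccc1F`: 2.9 mg/kg

All three compounds were tested in a functional assay on the whole organism with Rattus norvegicus as the target, in the maximal electroshock model; on this read-out lower numbers stand for an effect already at smaller amounts and higher numbers for an effect only at larger amounts of compound. On these numbers compound 3 stands second highest of the three. Its nearest neighbour is compound 2, whose number is lower by an amount that stays within the usual scatter, so the two cannot be told apart. Compound 1 sits furthest away, with a higher number than compound 3 by an amount beyond the scatter. Among the compounds with values here, no two of the measured compounds differ in only one place, so no single structural step among them can be read off directly.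

The new compound, compound 4, has the structure `Fc1ccccc1Cn1cnc2c(NC3CC3)ncnc21`. It differs from compound 3 by one change: cyclopropylamino in place of ethyl(methyl)amino on an aromatic carbon. Within the data shown here, nothing among the measured compounds shows how this particular exchange plays out in this assay; the amino groups of compound 1 and compound 2 are of a different kind again. With no guidance beyond the shared core and the closeness of compound 2 and compound 3, no step beyond the scatter is expected, and the estimated step of a 1.2-fold higher number from compound 3 to compound 4 (0.08 log units; within the scatter) reflects that. Compound 4 is therefore expected to give 3.5 mg/kg, with a range from 1.2 mg/kg to 10 mg/kg.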

Compound 4, dose for half-maximal effect: 5 mg/kg
Beside the measured number, compound 4's estimate is 1.4-fold (0.15 log units) below it; the range from low to high includes it.
By their numbers in this assay, from the lowest: compounds 2, 3, 4 and 1 (each within the scatter of the next, the first and the last beyond it).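

In this assay, putting cyclopropylamino in place of ethyl(methyl)amino on this aromatic carbon gives a 1.7-fold higher number from compound 3 to compound 4 (0.24 log units; within the scatter), so compound 3 and compound 4 cannot be told apart. Within the data shown here, this is the first comparison here in which only one place differs, and it concerns the carbon next to the ring nitrogen. The entering group brings a three-membered non-aromatic ring of carbon only and 1 hydrogen-bond donor, while the leaving group has no ring and 0 hydrogen-bond donors, yet the step stays within the usual scatter, and nothing measured here bears on the reason for this outcome.

Still open, going by these compounds, is whether a longer chain such as butylamino, or a larger ring such as cyclohexylamino or morpholine, would also stay within the scatter of compound 3 at this place. On these data alone, the fluorine patterns of compound 1 and compound 2 also leave a question, since both compounds differ from compound 3 and compound 4 in more than one place, so those steps cannot be read and the effect of this exchange on those patterns remains unknown.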